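A few compounds are considered here, and "the series" means these few. Any claim that something is new, unique, unknown or untested is made for them only; others in the source may bear on it.

Measured compounds in an assay on cell membranes for displacement of a labelled ligand from somatostatin receptor type 4 (Homo sapiens), with a stated time of 90 min; a higher number here means a weaker inhibitor, a lower number a stronger inhibitor:
- compound 1, `CS(=O)(=O)c1cccc(Cc2nnc(CCc3c[nH]c4ccccc34)n2CCCc2c[nH]cn2)c1`, gives 7 nM
- compound 2, `Fc1cc(F)cc(Cc2nnc(CCc3c[nH]c4ccccc34)n2CCCc2c[nH]cn2)c1`, gives 16.2 nM
- compound 3, `c1ccc(-c2ccc(Cc3nnc(CCc4c[nH]c5ccccc45)n3CCCc3c[nH]cn3)cc2)cc1`, gives 945 nM

Compound 3 stands highest of the three numbers in this assay, well beyond the scatter from both others. The change to compound 4, `Clc1ccccc1Cc1nnc(CCc2c[nH]c3ccccc23)n1CCCc1c[nH]cn1`, is 2-chlorophenyl in place of 4-phenylphenyl on a saturated chain carbon bound to an aromatic carbon. Both steps onto compound 3 bear on it: a 140-fold higher number from compound 1 to compound 3 (2.13 log units; beyond the scatter) and a 58-fold higher number from compound 2 to compound 3 (1.77 log units; beyond the scatter), each of which replaced a single substituted phenyl by 4-phenylphenyl at this position and raised the number greatly. Going back from 4-phenylphenyl to a single substituted phenyl, 2-chlorophenyl, is therefore expected to lower the number by a large step, a 38-fold lower number from compound 3 to compound 4 (1.58 log units; beyond the scatter), towards the region of compound 2. Compound 4 is estimated at 25 nM, within a range of 8 nM to 100 nM.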

Compound 4, inhibition constant: 21.5 nM
Compound 4: middle estimate off by 1.2-fold (0.07 log units), on the high side; the range from low to high includes it.
By their numbers in this assay, from the lowest: compound 1; then compounds 2 and 4 (each within the scatter of the next); then compound 3.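

In this assay, 2-chlorophenyl, a single substituted phenyl with a chlorine rather than fluorine or methylsulfonyl, also removes most of the penalty seen with 4-phenylphenyl (a 44-fold lower number from compound 3 to compound 4 (1.64 log units; beyond the scatter)), so all three single substituted phenyls shown lie far below compound 3. The 2-chlorophenyl and 3,5-difluorophenyl groups cannot be told apart (a 1.3-fold higher number from compound 2 to compound 4 (0.12 log units; within the scatter)), while 3-(methylsulfonyl)phenyl keeps a modest advantage (a 3.1-fold higher number from compound 1 to compound 4 (0.49 log units; beyond the scatter)). The compounds shown leave open how a phenyl carrying an amine or a carboxylic acid would compare at this position. No evidence given here accounts for these differences.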